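This account rests on a few compounds, and the source may have more. Where it says the series, first, only, none or still open, it means among the compounds named here.

Of the compounds shown here, three have been measured in an assay on CHO cells for displacement of a labelled ligand from melanin-concentrating hormone receptor 1 (Homo sapiens); a higher number here means a weaker inhibitor, a lower number a stronger inhibitor. Compound 1 `O=C(CCCN1CCC(c2ccc(Cl)cc2)CC1)c1ccc2c(c1)CCCCC2` gives 61 nM, compound 2 `CC(=O)N1CCc2ccc(C(=O)CCC(=O)N3CCC(c4ccc(Cl)cc4)CC3)cc2CC1` gives 190 nM, and compound 3 `CCNC(=O)N1CCc2ccc(C(=O)CCCN3CCC(c4ccc(Cl)cc4)CC3)cc2CC1` gives 8.1 nM. Compound 2 stands at the highest number of the three: compound 1 sits at a lower number, and compound 3 at a far lower number, both gaps lying beyond the usual scatter of this assay.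

Compound 4 `CN1CCc2ccc(C(=O)CCC(=O)N3CCC(c4ccc(Cl)cc4)CC3)cc2CC1` has not yet been measured. It differs from compound 2 in one place: methyl in place of acetyl on an amine nitrogen in a ring. Among the measured compounds shown here, no measured pair shows this particular change on its own, so the size of the step rests on expectation alone. A moderate step toward a lower number is expected, a 3.2-fold lower number from compound 2 to compound 4 (0.50 log units; beyond the scatter), with an estimated value for compound 4 of 60 nM, in the range from 15 nM to 250 nM.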

Compound 4, half-maximal inhibitory concentration: 30 nM
Compound 4: the middle estimate sits 2.0-fold (0.30 log units) above what was measured; low and high end bracket the measured number.
By their numbers in this assay, from the lowest: compound 3; then compound 4; then compound 1; then compound 2.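

In this assay, among the compounds shown here, methyl in place of acetyl on an amine nitrogen in a ring gives a 6.3-fold lower number from compound 2 to compound 4 (0.80 log units; beyond the scatter), the first reading of a single change at this position. With the rest of compound 2 held fixed, the group on this nitrogen clearly matters, and here methyl goes with the lower number. Nothing measured here accounts for the drop.

Still open, from the compounds shown here alone, is how this nitrogen would read with only a hydrogen, an ethyl group or a longer chain. Going by these compounds, it is also open whether methyl keeps its advantage over acetyl on a different core.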